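A few compounds are considered here, and "the series" means these few. Any claim that something is new, unique, unknown or untested is made for them only; others in the source may bear on it.

In an ADME assay on MT4 cells (Homo sapiens) for cytotoxicity, read by MTT assay, with a stated time of 4 days (on this read-out lower numbers stand for higher toxicity in this test and higher numbers for lower toxicity in this test), compound 1 (`CC(=O)Nc1ccc2oc(-c3ccccc3F)cc(=O)c2c1`) gives 205000 nM, compound 2 (`COc1ccccc1-c1oc2ccc(NC(C)=O)cc2c(=O)c1O`) gives 385000 nM and compound 3 (`COc1ccccc1-c1oc2ccc(NC(C)=O)cc2c(=O)c1OC`) gives 154000 nM. Compound 3 thus stands within the scatter of compound 1. Its gap to compound 2 lies beyond the scatter, and the measured step is modest: a 2.5-fold lower number from compound 2 to compound 3 (0.40 log units; beyond the scatter), with methyl in place of hydrogen on an oxygen on an aromatic ring.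

The next compound is compound 4 (`COc1c(-c2ccccc2F)oc2ccc(NC(C)=O)cc2c1=O`), which turns the 2-methoxyphenyl of compound 3 into 2-fluorophenyl: fluoro in place of methoxy on an aromatic carbon. Among the compounds with values here, no measured step covers this change, and the single step available concerns a different group, so it gives only a sense of scale. Compound 1 already carries the 2-fluorophenyl and gives 205000 nM, but it also differs from compound 4 elsewhere. Its value still offers no sign of a large move. No step beyond the scatter is therefore expected in this assay, although a modest move in either direction cannot be excluded. The estimated change is a 1.1-fold higher number from compound 3 to compound 4 (0.04 log units; within the scatter). Compound 4 is expected at 170000 nM, with an estimated range of 90000 nM to 320000 nM.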

Compound 4, half-maximal cytotoxic concentration: 180000 nM
Compound 4: the middle estimate sits 1.1-fold (0.02 log units) below what was measured; low and high end bracket the measured number.
By their numbers in this assay, from the lowest: compounds 3, 4, 1 and 2 (each within the scatter of the next, the first and the last beyond it).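

In this assay, within the data shown here, the step of a 1.2-fold higher number from compound 3 to compound 4 (0.07 log units; within the scatter) gives the first reading at this place on the aromatic ring, and fluoro and methoxy cannot be told apart there, so the change from 2-methoxyphenyl to 2-fluorophenyl alone leaves the read-out unmoved. Among these compounds, with the 2-fluorophenyl held constant, the step of a 1.1-fold lower number from compound 1 to compound 4 (0.06 log units; within the scatter) shows that methoxy in place of hydrogen on an aromatic carbon of the core also stays within the scatter, whereas the only step beyond the scatter so far remains a 2.5-fold lower number from compound 2 to compound 3 (0.40 log units; beyond the scatter), where a methyl replaces the hydrogen on an oxygen. No supporting data bear on why these two changes leave the number in place.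

Whether the hydroxy-to-methoxy step at the core keeps its size when the 2-fluorophenyl replaces the 2-methoxyphenyl remains open, since the series shown holds that pair only with the 2-methoxyphenyl. Also open, from the compounds shown here alone, is whether the tolerance at the ring position extends beyond fluoro and methoxy to an amine, a carboxylic acid or a longer alkoxy chain.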